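Swapping the Base Ring on a Weak Lactone Inhibitor

The compounds below may be only part of what the source reports. "The series", "measured", "known", "first", "only" and "open" are said of these compounds alone.

Compound 1 `Nc1ncn(CCC2(N)OC(=O)C(OCc3ccccc3)=C2OCc2ccccc2)c(=O)n1` was tested in a functional assay on HepG2 cells (Homo sapiens) for inhibition, read by MTT assay, with a stated time of 72 h; a higher number here means a weaker inhibitor, a lower number a stronger inhibitor. In this assay compound 1 reaches only > 100000 nM, which is a limit of the measurement rather than a number. Among the values shown it thus sits at the upper edge, as the limit of > 100000 nM in this assay, at which 1 of the 3 values shown sits, records. Compound 4 `Nc1ccn(CCC2(N)OC(=O)C(OCc3ccccc3)=C2OCc2ccccc2)c(=O)n1` keeps the shared core and differs from compound 1 in one place: a group of 8 heavy atoms (4 carbon, 3 nitrogen, 1 oxygen; one six-membered aromatic ring with 2 hetero atoms) in place of a group of 8 heavy atoms (3 carbon, 4 nitrogen, 1 oxygen; one six-membered aromatic ring with 3 hetero atoms), on a saturated chain carbon, two bonds along the chain from a saturated ring carbon. Two measured relatives carry the same entering ring on a different chain. In this assay compound 2 `Nc1ccn(C[C@H](O)[C@H]2OC(=O)C(OCc3ccccc3)=C2OCc2ccccc2)c(=O)n1` gives 44300 nM, and compound 3 `O=C1O[C@H]([C@@H](O)Cn2ccc(NC(=O)c3ccccc3)nc2=O)C(OCc2ccccc2)=C1OCc1ccccc1` gives 62200 nM. Among the measured compounds shown here, the only measured step, a 1.4-fold higher number from compound 2 to compound 3 (0.15 log units; within the scatter), concerns a benzoyl on the ring nitrogen and does not itself cover the swap of one base ring for another, so no measured step bears directly on the change from compound 1 to compound 4. The values of compounds 2 and 3 suggest that the entering ring sits with weak inhibition at best. Compound 4 is therefore expected to give 90000 nM, with a likely range from 30000 nM to 300000 nM. That estimate corresponds to an expected step of an at least 1.1-fold lower number from compound 1 to compound 4 (0.04 log units; that floor lies within the scatter), which may again end at a limit.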

Compound 4, half-maximal inhibitory concentration: > 100000 nM
Compound 4: no number, only a limit; the forecaster's own chance of this, stated with the estimate: 45%; middle value at least 1.1-fold (0.04 log units) away from the limit.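

Compound 1 and compound 4 both end at a limit rather than a number, so the step between them in this assay cannot be read: the limit of > 100000 nM in this assay, at which 2 of the 4 values shown sit. The compounds shown leave open whether exchanging one base ring for the other changes inhibition at all on this chain.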